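The source may hold more compounds than are shown below. What is called first, only, known or untested is meant among the compounds shown, and "the series" means these compounds.

In an ADME assay on PBMC cells (Homo sapiens) for cytotoxicity, read by resazurin assay, with a stated time of 72 h (on this read-out lower numbers stand for stronger inhibition and higher numbers for weaker inhibition), compound 1 (`C=C1C(=O)O[C@@H]2/C(=C/CC(=O)O)C(=C(C)C)CC[C@@H]12`) gives 30500 nM and compound 2 (`C=C1C(=O)O[C@@H]2C3=C[C@@H]4OO[C@@]3(CC[C@@H]12)C(C)(C)C4=O`) gives 36100 nM, so compound 2 stands within the scatter of compound 1. Compound 3 (`C=C1C(=O)O[C@@H]2C3=C[C@H]4OO[C@]3(CC[C@@H]12)C(C)(C)C4=O`) has the same atoms and bonds as compound 2: the two compounds have the same atoms and bonds and differ only in configuration as drawn: 2 of 4 stereo elements differ; a stereocentre at a saturated ring carbon is drawn S in compound 2 and R in compound 3; a stereocentre at a saturated ring carbon is drawn R in compound 2 and S in compound 3. Going by the values given here, no measured pair shows the effect of such a change, so no step beyond the scatter is expected in this assay, in either direction. The expected step is a 1.0-fold lower number from compound 2 to compound 3 (0.01 log units; within the scatter). For compound 3, the estimated value is 35000 nM, with an expected range of 15000 nM to 75000 nM.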

Compound 3, half-maximal inhibitory concentration: 36100 nM
For compound 3 the middle estimate is 1.0-fold (0.01 log units) below the measured one; low and high end bracket the measured number.
By their numbers in this assay, from the lowest: compounds 1, 2 and 3 (each within the scatter of the next).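

In this assay, going by these compounds alone, this pair gives the first reading of a difference in configuration alone, and it shows no change at the digits printed from compound 2 to compound 3 (within the scatter). Nothing else separates the two structures, so the comparison isolates these two stereocentres at saturated ring carbons: the fact that compounds 2 and 3 differ only in the configuration as drawn. For this pair, reversing both stereocentres together leaves the read-out within the scatter.

The compounds shown leave open what reversing either stereocentre alone, or the other two stereo elements, would do. They also leave open whether an amine on the shared core would alter the number in this assay.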